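Swapping Methoxypiperidine for Tetrahydroquinoline: Solubility Outlook

The compounds below may be only part of what the source reports. "The series", "measured", "known", "first", "only" and "open" are said of these compounds alone.

Measured so far:
compound 1, `COc1ccc2[nH]c(C(=O)N3CC(=O)N(Cc4ccccc4)[C@@H](CN4CCC(OC)CC4)C3)cc2c1`, solubility > 25000 nM
compound 2, `COc1ccc2[nH]c(C(=O)N3CC(=O)N(Cc4ccoc4)[C@@H](Cc4ccccc4)C3)cc2c1`, solubility 63600 nM

In a physicochemical assay for solubility, read by spectrophotometry, in phosphate buffer, with a stated time of 2 h, at pH 7.4 (a lower number here means a less soluble compound, a higher number a more soluble compound), compound 1 gives > 25000 nM, and this is a limit of the assay, not a number. Compound 2 shares the core of compound 1, and in this assay compound 2 gives 63600 nM. Among the compounds with values here, the two compounds differ in more than one place, so no single measured step links them; what can be said of compound 1 rests on the limit of > 25000 nM in this assay, at which 1 of the 2 values shown sits, alone.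

Compound 3, `COc1ccc2[nH]c(C(=O)N3CC(=O)N(Cc4ccccc4)[C@@H](CN4CCCc5ccccc54)C3)cc2c1`, has not yet been measured in this assay. It differs from compound 1 in one place: 1,2,3,4-tetrahydroquinolin-1-yl in place of 4-methoxypiperidin-1-yl on a saturated chain carbon bound to a saturated ring carbon.

Within the data shown here, with no measured step to draw on, the direction is judged from the change itself. Compound 3 is expected to be less soluble than compound 1, with the step from compound 1 to compound 3 expected to be an at least 2.0-fold lower number from compound 1 to compound 3 (0.31 log units; beyond the scatter), beyond the usual scatter. Compound 3 is therefore estimated at 12000 nM in this assay, with a range from 3000 nM to 40000 nM.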

Compound 3, solubility: 8500 nM
For compound 3 the middle estimate is 1.4-fold (0.15 log units) above the measured one; low and high end bracket the measured number.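

In this assay, putting 1,2,3,4-tetrahydroquinolin-1-yl in place of 4-methoxypiperidin-1-yl on a saturated chain carbon bound to a saturated ring carbon gives an at least 2.9-fold lower number from compound 1 to compound 3 (0.46 log units; beyond the scatter), a step that lies beyond the usual scatter. Compound 3 gives 8500 nM, so this position now has a reading that is a number, and a change of group here is seen to go with a lower number. For compound 1 the reading is a limit of the assay and not a number, so the step fixes only the least size of the difference, and its true size cannot be read: the limit of > 25000 nM in this assay, at which 1 of the 3 values shown sits.

The change swaps two things at once, adding an aromatic ring of carbon only and removing the methoxy group, and the compounds shown do not tell which of the two goes with the lower number. On these data alone, a plain piperidin-1-yl, a morpholine or an open-chain amine such as dimethylamino at the same place would stand between these two groups, and how any of them would read remains open.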